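The source may report more compounds than this note shows. Statements on the series, on what has been measured and on what is new or still open speak of the compounds shown alone.

Measured so far:
Compound 1, `CCCCCCCCc1ccc(OCC(=O)Cn2nnc(-c3ccc(C(=O)O)cc3)n2)cc1`, in an ADME assay on S9 fraction from liver (Rattus norvegicus) for metabolic stability, read by LC-MS, using NADPH, with a stated time of 30 min; a higher number here means that more of the compound is left, a lower number that less of the compound is left: < 5%
Compound 2, `CCCCCCCCc1ccc(OCC(=O)Cn2nnc(-c3cccc(C(=O)O)c3)n2)cc1`: < 5%
Compound 3, `CCCCCCCCc1ccc(OCC(=O)Cn2nnnc2-c2ccc(C(=O)O)cc2)cc1`: 6%

The value of compound 1 in this assay is a limit of the assay, not a number. The value of compound 2 is likewise a limit. Compound 3 is the only one of the three for which a number is read out. Compound 1 and compound 2 share one core; the change between them is 3-carboxyphenyl in place of 4-carboxyphenyl on an aromatic carbon, and its step that the two limits leave unreadable from compound 1 to compound 2 cannot be read because both values sit at the limit of < 5% in this assay, at which 2 of the 3 values shown sit. Compound 3 carries a different core, and how the two cores differ is not broken down here. Compound 4, `CCCCCCCCc1ccc(OCC(=O)Cn2nnnc2-c2cccc(C(=O)O)c2)cc1`, has not yet been measured. It differs from compound 3 by 3-carboxyphenyl in place of 4-carboxyphenyl on an aromatic carbon, the same kind of change as that between compound 1 and compound 2, though the place differs: in compound 1 the group sits two ring bonds from the ring atom that bears a large group, in compound 3 next to the ring atom that bears a large group. Since compound 3 gives 6%, compound 4 is expected to remain close to it, a step of a number 1 percentage points lower from compound 3 to compound 4 (within the scatter) that is estimated to lie within the scatter. Compound 4 is estimated at 5%, between 1% and 12%, with a real chance that only a limit is reported.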

Compound 4, percent of the compound remaining: < 5%
Compound 4 ended at the assay's limit; the forecaster's own chance of this, stated with the estimate: 50%; the middle value lies on the limit itself.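

In this assay compound 4 gives < 5% as a limit of the assay and not a number. Going by these compounds, on the core of compound 3, exchanging 4-carboxyphenyl for 3-carboxyphenyl gives a number at least 1 percentage points lower from compound 3 to compound 4 (that floor lies within the scatter) and so shows no drop beyond the usual scatter, though the true size of the step stays unknown. On the core of compound 1 the same exchange cannot be read, so the two steps cannot be compared and nothing shows whether the change carries the same way from one core to the other; 3-carboxyphenyl merely fails to lift either core off the limit: the limit of < 5% in this assay, at which 3 of the 4 values shown sit.

The compounds shown leave open whether any change away from the carboxyphenyl position would leave more of the compound in this assay at all. A shorter chain in place of the octyl chain, or an amide in place of the carboxylic acid, might bring the values into a readable range, but the compounds shown do not tell.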